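The compounds below may be only part of what the source reports. "The series", "measured", "known", "first", "only" and "open" are said of these compounds alone.

Compound 3 `Fc1ccc(-c2nc3ccc(Br)cn3c2-c2ccnc(NC3CCCC3)n2)cc1` stands at one of the cut-offs of an ADME assay on Vero cells (Chlorocebus sabaeus) for cytotoxicity; on this read-out lower numbers stand for higher toxicity in this test and higher numbers for lower toxicity in this test: in this test compound 3 returns only a limit, > 40000 nM. Compound 1 `COc1ccc(-c2nc3c(NC4CCCC4)cccn3c2-c2ccnc(NC3CCCC3)n2)cc1` likewise gives only a limit, > 10000 nM. Compound 2 `C=CCOc1cccc(-c2nc3c(NC4CCCC4)cccn3c2-c2ccnc(NC3CCCC3)n2)c1` also gives only a limit, > 40000 nM. For the measured compounds named here, because the limit of > 10000 nM in this assay, at which 1 of the 3 values shown sits, and the limit of > 40000 nM in this assay, at which 2 of the 3 values shown sit, account for all three values, the single measured step, a step that the two limits leave unreadable from compound 1 to compound 2, cannot be read, and no measured step bears on the change to compound 4 `Fc1ccc(-c2nc3ccc(NC4CCCC4)cn3c2-c2ccnc(NC3CCCC3)n2)cc1`, which is cyclopentylamino in place of bromo on an aromatic carbon. With nothing measured pointing to a shift, compound 4 is expected to remain at a limit as well, so that the estimated step of a number no higher from compound 3 to compound 4 (the limit leaves the size open) should lie within the scatter. On that basis compound 4 is estimated at 40000 nM, with a range from 10000 nM to 100000 nM.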

Compound 4, half-maximal cytotoxic concentration: > 40000 nM
Compound 4 ended at the assay's limit; the forecaster's own chance of this, stated with the estimate: 80%; the middle value lies on the limit itself.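

Compound 3 and compound 4 both return only a limit in this assay, and the step between them cannot be read. The compounds shown leave open whether cyclopentylamino in place of bromo changes cytotoxicity at all.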